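Chromone ether anilides: a carboxyphenyl replacement for Rho kinase

The compounds below may be only part of what the source reports. "The series", "measured", "known", "first", "only" and "open" are said of these compounds alone.

Measured compounds:
compound 1, `CC(C)(C)c1ccc(C(=O)Nc2cccc(NC(=O)COc3ccc4c(=O)ccoc4c3)c2)cc1`, 34 nM
compound 2, `Cc1cc(C(=O)Nc2cccc(NC(=O)COc3ccc4c(=O)ccoc4c3)c2)ccc1C(F)(F)F`, 43 nM

The two measured compounds share a common core and differ only in the aryl group on the carbonyl carbon of the benzamide. In an assay on isolated protein for inhibition of Rho-associated protein kinase 2 (Homo sapiens), read by scintillation counting, radiometric assay and 33P incorporation, with a stated time of 40 min, in the presence of a further agent that is not named here (on this read-out higher numbers stand for weaker inhibition and lower numbers for stronger inhibition), compound 1 gives 34 nM, and compound 2 gives 43 nM. Compound 2 has the higher of the two numbers, but the step of a 1.3-fold higher number from compound 1 to compound 2 (0.10 log units; within the scatter) lies within the scatter, so the two values show no real difference.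

Compound 3, `O=C(COc1ccc2c(=O)ccoc2c1)Nc1cccc(NC(=O)c2ccc(C(=O)O)cc2)c1`, is not yet measured. The change from compound 2 to compound 3 is a group of 9 heavy atoms (7 carbon, 2 oxygen; one six-membered aromatic ring of carbon only) in place of a group of 11 heavy atoms (8 carbon, 3 fluorine; one six-membered aromatic ring of carbon only), on a carbonyl carbon. For the measured compounds named here, the only measured step that bears on this position is the one from compound 1 to compound 2, which was within the scatter; it shows that exchanging one aromatic ring of carbon for another at this carbonyl carbon changed little. Going by the values given here, a 4-carboxyphenyl group, with its hydrogen-bond donor and acceptor, is a different kind of change, and no measured step covers it. Compound 3 is therefore expected to give a modestly higher number, a 3.5-fold higher number from compound 2 to compound 3 (0.54 log units; beyond the scatter), with wide uncertainty. The estimate for compound 3 is 150 nM, expected between 40 nM and 600 nM.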

Compound 3, half-maximal inhibitory concentration: 2030 nM
Compound 3: middle estimate off by 14-fold (1.13 log units), on the low side, and the stated range ends below it.
By their numbers in this assay, from the lowest: compounds 1 and 2 (each within the scatter of the next); then compound 3.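

In this assay, the earlier step had suggested that this carbonyl carbon accepts different aromatic groups with little consequence, but the entry of 4-carboxyphenyl shows that it does not accept every such group: the result is a 47-fold higher number from compound 2 to compound 3 (1.67 log units; beyond the scatter), a large loss of inhibition. The comparison with compound 1 isolates the change to a single group, carboxy in place of tert-butyl on an aromatic carbon, and gives a 60-fold higher number from compound 1 to compound 3 (1.78 log units; beyond the scatter), also large. The position is therefore sensitive to the group carried on this aromatic ring, though nothing available here accounts for the size of the loss.

The compounds shown leave open whether the loss is specific to the free carboxylic acid, since a methyl ester or a primary carboxamide in its place could show whether inhibition returns towards the values of compound 1 and compound 2. They also leave open whether a carboxymethyl group, which holds the acid on a longer chain, would give a similarly high number in this assay.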